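Iodo for ethynyl in a cell-growth series: working notes

This account rests on a few compounds, and the source may have more. Where it says the series, first, only, none or still open, it means among the compounds named here.

Measured so far in a functional assay on CCRF-CEM cells (Homo sapiens), read by MTT assay, with a stated time of 72 h; on this read-out higher numbers stand for weaker inhibition and lower numbers for stronger inhibition:
compound 1 `C#Cc1cn([C@@H]2O[C@H](CO)[C@@H](O)[C@H]2O)c2ncnc(NC)c12`: > 20000 nM, a limit of the assay
compound 2 `C#Cc1cn([C@@H]2O[C@H](CO)[C@@H](O)[C@H]2O)c2nc(C)nc(N)c12`: > 20000 nM, a limit of the assay
compound 3 `Cc1nc(N)c2c(I)cn([C@@H]3O[C@H](CO)[C@@H](O)[C@H]3O)c2n1`: 9030 nM

The difference between the cores of compound 1 and compound 2 is not broken down here. From compound 2 to compound 3 the change is iodo in place of ethynyl on an aromatic carbon, and it gave an at least 2.2-fold lower number from compound 2 to compound 3 (0.34 log units; beyond the scatter). The same kind of change leads from compound 1 to compound 4 `CNc1ncnc2c1c(I)cn2[C@@H]1O[C@H](CO)[C@@H](O)[C@H]1O`, namely (iodo in place of ethynyl on an aromatic carbon); the place is described in the same words for both pairs. Compound 1 is known only through (the limit of > 20000 nM in this assay, at which 2 of the 3 values shown sit), so the size of its step cannot be anchored. Compound 4 is expected to show an at least 2.0-fold lower number from compound 1 to compound 4 (0.30 log units; that floor lies within the scatter) in this assay, resting on the step from compound 2 to compound 3. The estimate for compound 4 is 10000 nM, between 3000 nM and 30000 nM.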

Compound 4, half-maximal inhibitory concentration: > 100000 nM
Compound 4: only a limit was reported; the forecaster's own chance of this, stated with the estimate: 40%; middle value at least 10-fold (1.00 log units) from the limit.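

Compound 1 and compound 4 are both known only as limits in this assay, and the step between them cannot be read. As far as these compounds go, whether iodo in place of ethynyl acts on the core of compound 1 as on the core of compound 2 stays open.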